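A few compounds are considered here, and "the series" means these few. Any claim that something is new, unique, unknown or untested is made for them only; others in the source may bear on it.

Measured so far:
- compound 1 `Nc1ccnc(Nc2ccc(Oc3ccc(Cl)cc3)cc2)c1` gives 14 mL.min-1.g-1 in an in vitro ADME assay on microsomes from liver (Homo sapiens) for metabolic stability; on this read-out lower numbers stand for slow clearance and higher numbers for fast clearance
- compound 2 `Nc1cc(Nc2ccc(Oc3ccc(Cl)cc3)cc2)cnn1` gives 20 mL.min-1.g-1 in this assay

Compound 2 stands within the scatter of compound 1, so the pair counts as level. Compound 3 `Nc1nsc(Nc2ccc(Oc3ccc(Cl)cc3)cc2)n1` differs from compound 2 by 3-amino-1,2,4-thiadiazol-5-yl in place of 6-aminopyridazin-4-yl on a nitrogen on an aromatic ring and is not yet measured. Going by the values given here, the one measured step bearing on this is a 1.4-fold higher number from compound 1 to compound 2 (0.15 log units; within the scatter) and it also exchanges the group on a nitrogen on an aromatic ring. Among the compounds with values here, no measured compound carries a five-membered aromatic ring, so that step is a weak guide. In this assay no shift beyond the scatter is expected. The expected change is a 1.1-fold lower number from compound 2 to compound 3 (0.05 log units; within the scatter) and no more. The estimate for compound 3 is 18 mL.min-1.g-1 (range 8 mL.min-1.g-1 to 45 mL.min-1.g-1).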

Compound 3, intrinsic clearance in microsomes: < 14 mL.min-1.g-1
Compound 3: no number, only a limit; the forecaster's own chance of this, stated with the estimate: 5%; at least 1.2-fold (0.10 log units) between middle value and limit.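

Compound 3 gives only a limit in this assay, not a number: the limit of < 14 mL.min-1.g-1 in this assay, at which 1 of the 3 values shown sits.

On these data alone, the 3-amino-1,2,4-thiadiazol-5-yl group in place of 6-aminopyridazin-4-yl gives an at least 1.4-fold lower number from compound 2 to compound 3 (0.15 log units; that floor lies within the scatter), so the true size of this change stays open. The position on a nitrogen on an aromatic ring thus accepts a five-membered aromatic ring with sulfur without a higher number, which the six-membered groups of compound 1 and compound 2 could not show. The 3-amino-1,2,4-thiadiazol-5-yl group in place of 4-aminopyridin-2-yl gives a number no higher from compound 1 to compound 3 (the limit leaves the size open).

Still open, as far as these compounds go, is how a methyl group in place of the amino group on the thiadiazole ring would read in this assay.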